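The compounds below may be only part of what the source reports. "The series", "measured", "known", "first", "only" and "open" are said of these compounds alone.

In a functional assay (muscle tissue) with Cavia porcellus as the target (on this read-out higher numbers stand for an effect only at larger amounts of compound and lower numbers for an effect already at smaller amounts), compound 3 (`COC(=O)C1=C(C)N=C(C)/C(=C(\O)OC)C1c1ccc(I)cc1`) gives 22900 nM and lies within the scatter of compound 1 (`COC(=O)C1=C(C)N=C(C)/C(=C(\O)OC)C1c1ccccc1N`) at 39800 nM in the series, while compound 2 (`COC(=O)C1=C(C)N=C(C)/C(=C(\O)OC)C1c1cccc(N(C)C)c1`) gives 891 nM and stands well under both. Compound 4 (`COC(=O)C1=C(C)N=C(C)/C(=C(\O)OC)C1c1cccc(C)c1`) brings 3-methylphenyl in place of 4-iodophenyl on a saturated ring carbon with 3-methylphenyl in place of 4-iodophenyl on a saturated ring carbon. For the measured compounds named here, the one measured step, a 1.7-fold lower number from compound 1 to compound 3 (0.24 log units; within the scatter) for an exchange of the substituted phenyl group, stayed small. Compound 2 at 891 nM shows that much lower numbers occur with this shared core. A moderate move to a lower number is therefore expected in this assay with wide uncertainty. The estimated step is a 5.7-fold lower number from compound 3 to compound 4 (0.76 log units; beyond the scatter) as a working figure. Compound 4 is expected at 4000 nM with an estimated range of 700 nM to 22000 nM for now.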

Compound 4, half-maximal effective concentration: 110 nM
Estimate against measurement, compound 4: 36-fold (1.56 log units) above; the measured number lies below the stated range.
By their numbers in this assay, from the lowest: compound 4; then compound 2; then compounds 3 and 1 (each within the scatter of the next).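

For the compounds shown here, at the saturated ring carbon, exchanging the aryl group can move the number far more than the step among the earlier compounds suggested: this assay shows a 210-fold lower number from compound 3 to compound 4 (2.32 log units; beyond the scatter) and a 360-fold lower number from compound 1 to compound 4 (2.56 log units; beyond the scatter). With the aryl attachment kept, methyl in place of dimethylamino on an aromatic carbon still gives an 8.1-fold lower number from compound 2 to compound 4 (0.91 log units; beyond the scatter). No measured evidence accounts for these steps.

The comparison with compound 3 changes both the substituent and its ring place, so their contributions remain unseparated. 3-Iodophenyl, 4-methylphenyl or 3-ethylphenyl would test this.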